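Swapping the Fluorine Pattern on the Benzyl Arm

The source may hold more compounds than are shown below. What is called first, only, known or untested is meant among the compounds shown, and "the series" means these compounds.

Compound 1 `CCOC(=O)/C(O)=C/C(=O)c1cn(Cc2cc(F)c(F)c(F)c2)c2cccc(OC)c12` is the ethyl ester of this small set, and in an ADME assay on MT4 cells (Homo sapiens) for cytotoxicity, read by MTT assay (a lower number here means that less compound is tolerated, a higher number that more compound is tolerated), compound 1 gives 33400 nM, the second highest of the three numbers. In this assay compound 2 `COc1cccc2c1c(C(=O)/C=C(\O)C(=O)O)cn2Cc1cc(F)ccc1F` gives 46200 nM, and compound 3 `COc1cccc2c1c(C(=O)/C=C(\O)C(=O)O)cn2Cc1cc(F)c(F)c(F)c1` gives 23300 nM; both lie within the scatter of compound 1, as a 1.4-fold lower number from compound 1 to compound 3 (0.16 log units; within the scatter) shows for the ester-to-acid change. Compound 4 `CCOC(=O)/C(O)=C/C(=O)c1cn(Cc2cccc(F)c2F)c2cccc(OC)c12` carries 2,3-difluorophenyl in place of 3,4,5-trifluorophenyl on a saturated chain carbon bound to an aromatic nitrogen. For the measured compounds named here, the one measured step that bears on changing the fluorine pattern at this position is a 2.0-fold lower number from compound 2 to compound 3 (0.30 log units; within the scatter), which stayed within the scatter. The step from compound 1 to compound 4 is therefore expected to be a 1.0-fold lower number from compound 1 to compound 4 (0.01 log units; within the scatter), with no direction beyond the scatter. Compound 4 is accordingly estimated at 33000 nM in this assay, within a range of 15000 nM to 70000 nM.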

Compound 4, half-maximal cytotoxic concentration: 21100 nM
Compound 4: the middle estimate sits 1.6-fold (0.19 log units) above what was measured, within the range that was stated.
By their numbers in this assay, from the lowest: compounds 4, 3, 1 and 2 (each within the scatter of the next, the first and the last beyond it).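

In this assay, the step on the ethyl ester, a 1.6-fold lower number from compound 1 to compound 4 (0.20 log units; within the scatter), extends what the acids had shown: a change of fluorine pattern at this position stays within the scatter on the ester as well. Here, the 3,4,5-trifluorobenzyl to 2,3-difluorobenzyl change removes one fluorine and moves the others without carrying the number beyond that scatter. As far as these compounds go, it remains open whether a plain benzyl group, or a benzyl group bearing chlorine or trifluoromethyl, would also stay within the scatter on this ester. No measurement shown offers an explanation for this result.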